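Amide nitrogen variation on the shared core

A few compounds are considered here, and "the series" means these few. Any claim that something is new, unique, unknown or untested is made for them only; others in the source may bear on it.

Three amides on the shared core have been measured in a functional assay on the whole organism (strain Wistar) for inhibition, with Rattus norvegicus as the target, read by paw edema, with stated times of 60 min and 6 h, at a dose of 100 mg/kg by the oral route; a lower number here means less inhibition, a higher number more inhibition at the dose given (going by the name of the read-out). Compound 1 `COc1cc2c(cc1OC)C(CC(=O)NC(C)C)CC2` gives 37%, compound 3 `COc1cc2c(cc1OC)C(CC(=O)NC(C)(C)C)CC2` gives 31.5%, and compound 2 `CCCCNC(=O)CC1CCc2cc(OC)c(OC)cc21` gives 24.1%. Compound 2 stands lowest of the three numbers: the step of a number 12.9 percentage points lower from compound 1 to compound 2 (beyond the scatter) lies beyond the scatter, while a number 7.4 percentage points higher from compound 2 to compound 3 (within the scatter) lies within it. The unmeasured compound 4 `COc1cc2c(cc1OC)C(CC(=O)N1CCCC1)CC2` differs from compound 2 by pyrrolidin-1-yl in place of butylamino on a carbonyl carbon. All measured steps alter the group on the amide-type nitrogen: a number 12.9 percentage points lower from compound 1 to compound 2 (beyond the scatter) is modest, and a number 5.5 percentage points lower from compound 1 to compound 3 (within the scatter) and a number 7.4 percentage points higher from compound 2 to compound 3 (within the scatter) remain within the scatter. None of them removes the single hydrogen-bond donor or introduces a five-membered non-aromatic ring, so they bear only loosely on the change to compound 4. The three measured numbers span a narrow band, and compound 2 sits at its lower edge. The expected step of a number 3.9 percentage points higher from compound 2 to compound 4 (within the scatter) is therefore estimated to stay within the scatter, if anything upward. The estimate for compound 4 in this assay is 28%, with a range from 17% to 40%.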

Compound 4, a percentage reported as inhibition, in the whole organism at one dose (the size of the read-out at that dose, not a potency): 22.2%
The estimate for compound 4 lay 5.8 percentage points above the measured number, and the stated range covers the measured number.
By their numbers in this assay, from the lowest: compounds 4, 2, 3 and 1 (each within the scatter of the next, the first and the last beyond it).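

In this assay, pyrrolidin-1-yl in place of butylamino on a carbonyl carbon removes the amide hydrogen and brings in a five-membered non-aromatic ring, yet a number 1.9 percentage points lower from compound 2 to compound 4 (within the scatter) does not separate the two compounds. The tertiary amide is likewise not separated from the tert-butyl amide by a number 9.3 percentage points lower from compound 3 to compound 4 (within the scatter), whereas a number 14.8 percentage points lower from compound 1 to compound 4 (beyond the scatter) is a modest step that parallels a number 12.9 percentage points lower from compound 1 to compound 2 (beyond the scatter), so compound 1 is the only amide here set apart from compound 4. No supporting data bear on what underlies these numbers.

Open, from the compounds shown here alone, is whether piperidin-1-yl, morpholin-4-yl or dimethylamino on the carbonyl carbon would stay level with compound 4. Also open, going by these compounds, is how a carboxylic acid in that place, with no amide nitrogen at all, would read in this assay.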